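The source may hold more compounds than are shown below. What is called first, only, known or untested is meant among the compounds shown, and "the series" means these compounds.

Compound 1 `Cc1cccc(-n2c(-c3coc4cc(C)c(Cl)cc4c3=O)nc(-c3ccccc3)c2-c2ccccc2)c1` gives 12500 nM
Compound 2 `Cc1cc2occ(-c3nc(-c4ccccc4)c(-c4ccccc4)n3-c3ccccc3Cl)c(=O)c2cc1Cl` gives 12500 nM

In a functional assay on A549 cells (Homo sapiens) for inhibition, read by MTT assay, with a stated time of 72 h (on this read-out lower numbers stand for stronger inhibition and higher numbers for weaker inhibition), compound 2 sits at 12500 nM and stands level with compound 1, its nearest neighbour. Next comes compound 3 `Cc1ccc(-n2c(-c3coc4cc(C)c(Cl)cc4c3=O)nc(-c3ccccc3)c2-c2ccccc2)cc1` with the change 4-methylphenyl in place of 2-chlorophenyl on an aromatic nitrogen on an aromatic nitrogen, 4-methylphenyl in place of 2-chlorophenyl. Among the measured compounds shown here, the one measured step that bears on this shows no change at the digits printed from compound 1 to compound 2 (within the scatter) on an aromatic nitrogen as well, with 2-chlorophenyl in place of 3-methylphenyl. For the measured compounds named here, no measured compound carries 4-methylphenyl, so the expectation rests on that single step. In this assay no shift beyond the scatter is expected, and neither direction is favoured. The expected step of no change at the digits printed from compound 2 to compound 3 (within the scatter) stays within the scatter. For compound 3 the estimate is 12500 nM within an expected range of 6000 nM to 25000 nM for this measurement.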

Compound 3, half-maximal inhibitory concentration: 12500 nM
For compound 3 middle estimate and measured number coincide at the digits printed; the range from low to high includes it.
By their numbers in this assay, from the lowest: compounds 1, 2 and 3 (each within the scatter of the next).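

Exchanging 3-methylphenyl for 4-methylphenyl on the aromatic nitrogen gives no change at the digits printed from compound 1 to compound 3 (within the scatter) in this assay and so adds a second methylphenyl comparison to the series. Exchanging 2-chlorophenyl for 4-methylphenyl gives no change at the digits printed from compound 2 to compound 3 (within the scatter) and extends the flat reading at this position to three aryl groups, with the chlorine-bearing ring reading the same as both methyl-bearing rings. No measured information available here explains this flat reading.

From the compounds shown here alone, it remains open whether any group on this nitrogen can move the value beyond the scatter, for example a phenyl ring bearing an amine or a carboxylic acid, or a longer alkyl chain in place of the ring. Going by these compounds, all three compounds also share the two phenyl groups and the rest of the core, so the effect of changes at those places remains open.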